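The source may report more compounds than this note shows. Statements on the series, on what has been measured and on what is new or still open speak of the compounds shown alone.

Three measured compounds share one core and differ in two places: the aryl on the sulfonamide nitrogen and the ring joined to the oxadiazole through the saturated chain carbon. Compound 1 `CCc1ccccc1N(Cc1nnc(Cc2ccc(OC)cc2)o1)S(=O)(=O)c1ccc(C)cc1` gives 631 nM in a functional assay on CHO cells for antagonist activity at prostaglandin E2 receptor EP1 subtype (Homo sapiens), read by FLIPR and calcium flux; a higher number here means a weaker inhibitor, a lower number a stronger inhibitor. Compound 2 `COc1ccc(Cc2nnc(CN(c3cccc(Cl)c3C)S(=O)(=O)c3ccc(C)cc3)o2)cc1` gives 39.8 nM in this assay, and a 16-fold lower number from compound 1 to compound 2 (1.20 log units; beyond the scatter). Compound 3 `Cc1ccc(S(=O)(=O)N(Cc2nnc(Cc3ccc(F)cc3)o2)c2cccc(Cl)c2C)cc1` gives 501 nM in this assay, with a 13-fold higher number from compound 2 to compound 3 (1.10 log units; beyond the scatter). Compound 3 therefore stands second highest of the three numbers, within the scatter of compound 1 and far above compound 2.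

Compound 4 `Cc1ccc(S(=O)(=O)N(Cc2nnc(Cc3cccc(Cl)c3)o2)c2cccc(Cl)c2C)cc1` differs from compound 3 by 3-chlorophenyl in place of 4-fluorophenyl on a saturated chain carbon bound to an aromatic carbon. Of the two measured steps, only a 13-fold higher number from compound 2 to compound 3 (1.10 log units; beyond the scatter) concerns this ring, and it shows that one substituent change there can move the number by a large amount; the other step, a 16-fold lower number from compound 1 to compound 2 (1.20 log units; beyond the scatter), sits on the sulfonamide nitrogen and says nothing about this ring. Going by the values given here, no measured compound carries a 3-chlorophenyl here, so the direction of the coming step rests on little. He expects a modest change at most, a 1.3-fold lower number from compound 3 to compound 4 (0.10 log units; within the scatter), and estimates that compound 4 will give 400 nM in this assay, within a range from 100 nM to 1600 nM.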

Compound 4, inhibition constant: 2000 nM
Compound 4: middle estimate off by 5.0-fold (0.70 log units), on the low side; measured number above the stated range.
By their numbers in this assay, from the lowest: compound 2; then compounds 3 and 1 (each within the scatter of the next); then compound 4.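

With the 3-chloro-2-methylphenyl on the sulfonamide nitrogen held constant, the ring on the saturated chain carbon now has three measured forms in this assay, and the earlier compounds had shown only one step among them. Replacing 4-fluorophenyl with 3-chlorophenyl gives a 4.0-fold higher number from compound 3 to compound 4 (0.60 log units; beyond the scatter) and so shows that this position still responds to a change between two halogen-bearing rings, while replacing 4-methoxyphenyl with 3-chlorophenyl gives a 50-fold higher number from compound 2 to compound 4 (1.70 log units; beyond the scatter), the widest gap among the compounds shown, which places the three rings in the order 4-methoxyphenyl, 4-fluorophenyl, 3-chlorophenyl from the lowest number to the highest. The compounds shown offer no measurement that accounts for this order.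

The step from compound 3 to compound 4 changes both the halogen and where it sits on the ring, so the compounds shown cannot separate the two, and a 4-chlorophenyl or a 3-fluorophenyl at this place would be needed to do so. On these data alone, it also stays open how an unsubstituted phenyl or a 3-methoxyphenyl would read here, and whether the same order holds with 2-ethylphenyl on the sulfonamide nitrogen.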